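The compounds below may be only part of what the source reports. "The series", "measured", "known", "first", "only" and "open" are said of these compounds alone.

Values in a functional assay on IMR-32 cells (Homo sapiens) for antiproliferative activity, read by sulforhodamine B assay, with a stated time of 48 h (on this read-out lower numbers stand for stronger inhibition of growth and higher numbers for weaker inhibition of growth), are as follows
- compound 1 `COc1ccc2cc(-c3cn(CCCN4C(=O)COc5ccccc54)nn3)ccc2c1` gives 1300 nM
- compound 2 `O=C1COc2ccccc2N1CCCn1cc(-c2cccnc2)nn1` gives 860 nM

Compound 2 stands at 860 nM and compound 1 at 1300 nM, so the two values lie within the usual scatter of each other and neither can be ranked above the other.

Compound 3 `O=C1COc2ccccc2N1CCCn1cc(C2(O)CCCCC2)nn1` carries 1-hydroxycyclohexyl in place of pyridin-3-yl on an aromatic carbon of a five-membered aromatic ring with 3 nitrogen (1-hydroxycyclohexyl in place of pyridin-3-yl on an aromatic carbon). Among the compounds with values here, no measured step covers this change, so the expectation is a judgement with a wide margin. A moderate move toward weaker inhibition of growth in this assay is expected, a little beyond the scatter. The estimated step is a 2.3-fold higher number from compound 2 to compound 3 (0.37 log units; beyond the scatter). For compound 3 the estimated value is 2000 nM, with an expected range of 600 nM to 7000 nM.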

Compound 3, concentration for 50% growth inhibition: 1200 nM
For compound 3 the middle estimate is 1.7-fold (0.22 log units) above the measured one; the measured number falls inside the stated range.
By their numbers in this assay, from the lowest: compounds 2, 3 and 1 (each within the scatter of the next).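

In this assay, the aromatic carbon of the five-membered aromatic ring with 3 nitrogen accepts a substituent with a non-aromatic ring of carbon only: 1-hydroxycyclohexyl in place of pyridin-3-yl gives a 1.4-fold higher number from compound 2 to compound 3 (0.14 log units; within the scatter), so neither an aromatic ring nor a ring nitrogen in this substituent is needed for a value in this range. The same exchange introduces a hydrogen-bond donor that pyridin-3-yl lacks, and the read-out does not separate the two compounds. No supporting data are available to explain this result.

On these data alone, it remains open whether plain cyclohexyl without the hydroxyl group would hold this level, and how an amine or a carboxylic acid on this ring would read. A longer chain in place of the present linking chain is also untested in the compounds shown.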